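The source may hold more compounds than are shown below. What is called first, only, known or untested is meant among the compounds shown, and "the series" means these compounds.

Measured compounds:
- compound 1, `CCCNC(=O)/N=C(\N)Nc1cccc(-c2csc(N)n2)c1`: "not determined" (no result reported)
- compound 2, `CCCCCCNC(=O)/N=C(\N)NCCCc1sc(N)nc1C`: 0.28
- compound 3, `CCCCCCNC(=O)/N=C(\N)NC1CCc2nc(N)sc2C1`: "not determined" (no result reported)

Of the three compounds measured in a functional assay on HEK293T cells for agonist activity at histamine H2 receptor (Homo sapiens), read by beta-arrestin recruitment (on this read-out lower numbers stand for smaller maximal responses and higher numbers for larger maximal responses), only compound 2 comes with a number: in this assay compound 2 gives 0.28. Among the measured compounds shown here, compound 1 and compound 3 have no reported result, so compound 2 stands alone and no comparison between measured compounds can be drawn.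

The next compound, compound 4 with structure `CCCCCNC(=O)/N=C(\N)NCCCc1sc(N)nc1C`, differs from compound 2 in one place: hydrogen in place of methyl on a saturated chain carbon, five bonds along the chain from an amide-type nitrogen. The rest of the molecule is unchanged.

For the measured compounds named here, with no measured pair to lean on, the step from compound 2 to compound 4 is expected to stay within the usual scatter of this assay, with no preferred direction. The account therefore expects the maximal response of compound 4 to sit close to that of compound 2, and estimates a step of no change at the digits printed from compound 2 to compound 4 (within the scatter). For compound 4 the estimated value in this assay is 0.28, with a likely range from 0.15 to 0.42.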

Compound 4, intrinsic activity: the largest response reached, as a fraction of the reference agonist's: 0.15
Compound 4: middle estimate off by 0.13, on the high side; the range from low to high includes it.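

Hydrogen in place of methyl on a saturated chain carbon, five bonds along the chain from an amide-type nitrogen, gives a number 0.13 lower from compound 2 to compound 4 (beyond the scatter) in this assay, so this position is not silent for the maximal response, and of this pair the longer chain gives the larger response. Among the compounds shown here, as the only measured pair, this step gives a direction and size for one change and no trend along the chain. The data shown offer no measurement that would explain the step.

On these data alone, it remains open whether a shorter chain such as propyl, a longer chain such as octyl, or a chain ending in a hydroxyl group or a cyclohexyl ring would extend this direction. For the compounds shown here, compound 1 and compound 3 carry no number, so no steps to them can be read.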